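A few compounds are considered here, and "the series" means these few. Any claim that something is new, unique, unknown or untested is made for them only; others in the source may bear on it.

Measured so far, in a functional assay on aorta (strain Wistar) for inhibition, with Thoracic aorta (Rattus norvegicus) as the target; a higher number here means a weaker inhibitor, a lower number a stronger inhibitor:
- compound 1 `COc1nc(-c2cc3ccccc3o2)cc(-c2ccc(Cl)cc2Cl)c1C#N`: 322000 nM
- compound 2 `COc1nc(-c2cc3ccccc3o2)cc(-c2cccs2)c1C#N`: 163000 nM

For the measured compounds named here, compound 2 and compound 1 lie within the scatter of each other, the only step between them being a 2.0-fold lower number from compound 1 to compound 2 (0.30 log units; within the scatter). Compound 3 `COc1nc(-c2cc3ccccc3o2)cc(-c2ccc(C)o2)c1C#N` is not yet measured. It differs from compound 2 by 5-methylfuran-2-yl in place of thiophen-2-yl on an aromatic carbon. Going by the values given here, the one measured step that bears on it, a 2.0-fold lower number from compound 1 to compound 2 (0.30 log units; within the scatter), exchanged the same position and stayed within the scatter, so compound 3 is expected to show no step beyond the scatter in this assay, a 1.0-fold higher number from compound 2 to compound 3 (0.02 log units; within the scatter). Compound 3 is therefore estimated at 170000 nM, with a range from 60000 nM to 450000 nM.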

Compound 3, half-maximal inhibitory concentration: 285000 nM
The estimate for compound 3 lay 1.7-fold (0.22 log units) below the measured number; low and high end bracket the measured number.
By their numbers in this assay, from the lowest: compounds 2, 3 and 1 (each within the scatter of the next).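

Across this assay, a third group on this aromatic carbon, opposite the ring nitrogen, again stays within the scatter, with a 1.7-fold higher number from compound 2 to compound 3 (0.24 log units; within the scatter) and a 1.1-fold lower number from compound 1 to compound 3 (0.05 log units; within the scatter) as its steps. The assay therefore does not separate 5-methylfuran-2-yl, thiophen-2-yl and 2,4-dichlorophenyl, and the swap from thiophen-2-yl to 5-methylfuran-2-yl, which exchanges sulfur for oxygen and adds a methyl together, cannot be split into separate contributions. No available evidence accounts for this result. From the compounds shown here alone, whether an amine or a carboxylic acid here would move the number beyond the scatter remains open, as does the effect of replacing the methoxy or cyano group on the shared core.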